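A few compounds are considered here, and "the series" means these few. Any claim that something is new, unique, unknown or untested is made for them only; others in the source may bear on it.

Measured compounds:
- compound 1, `C=C(C)c1ccc(N2CCN(C(=O)c3oc(C)nc3-c3ccccc3)CC2)cc1`, in a functional assay on HL-60 cells (Homo sapiens) for inhibition, read by MTT assay, with a stated time of 72 h (a higher number here means a weaker inhibitor, a lower number a stronger inhibitor), compound 1 gives "not active" (no number reported)
- compound 2, `Cc1nc(-c2ccccc2F)c(C(=O)N2CCN(c3cc(Cl)cc(Cl)c3)CC2)o1`, compound 2 gives 60.2 nM
- compound 3, `CCC[C@H](Nc1nc(-c2ccc(NC(=O)NCC)c(OC)c2)ncc1C)c1cccnc1`, compound 3 gives 112 nM

Compound 1 stands apart: in this assay compound 1 gives only "not active" (no number reported), so no number can be placed against the other two. Compound 2 shares its core with compound 1 but carries a different group on the amine nitrogen in a ring, and compound 3 is built on another core altogether. The untested compound 4, `Cc1nc(-c2ccccc2)c(C(=O)N2CCN(c3cccc(C(F)(F)F)c3)CC2)o1`, takes the core of compound 1 and makes one change: 3-(trifluoromethyl)phenyl in place of 4-(1-methylethenyl)phenyl on an amine nitrogen in a ring. Going by the values given here, no measured step between neighbours exists to lean on, so the size of the step in this assay can only be judged from the two endpoints that are known: compound 1 without a number, compound 2 with one. A move toward measurable inhibition is expected, possibly a large one, though a repeat of the outcome of compound 1 cannot be ruled out. For compound 4 the expected value is 200 nM, with a range from 40 nM to 3000 nM.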

Compound 4, half-maximal inhibitory concentration: 153 nM
The estimate for compound 4 lay 1.3-fold (0.12 log units) above the measured number, within the range that was stated.
By their numbers in this assay, from the lowest: compounds 2, 3 and 4 (each within the scatter of the next, the first and the last beyond it).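

In this assay, going by these compounds alone, compound 1 gives "not active" (no number reported) and compound 4 gives 153 nM so no step between the two can be read. The compounds shown leave open which feature of the 3-(trifluoromethyl)phenyl group goes with measurable inhibition. No measured evidence bears on this result.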